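Ethenyl cyclopropyl amide against a row of limits

The source may hold more compounds than are shown below. What is called first, only, known or untested is meant among the compounds shown, and "the series" means these compounds.

In a functional assay on KB cells (Homo sapiens) for inhibition, read by sulforhodamine B assay, with a stated time of 72 h (on this read-out lower numbers stand for stronger inhibition of growth and higher numbers for weaker inhibition of growth), compound 1 `O=C(CCc1ccncc1-c1ccc2ccccc2c1)N1CCOCC1` reads > 10000 nM as a limit only. Compound 2 `CNC(=O)CCc1ccncc1-c1ccc2ccccc2c1` reads > 10000 nM as a limit too, so it offers no number to start from. Among the measured compounds shown here, the one measured step is a step that the two limits leave unreadable from compound 1 to compound 2 and gives no size, and the evidence stops at the limit of > 10000 nM in this assay, at which 3 of the 3 values shown sit, for now. Compound 4 `O=C(/C=C/c1ccncc1-c1ccc2ccccc2c1)NC1CC1` has 2-(cyclopropylcarbamoyl)ethenyl in place of 2-(methylcarbamoyl)ethyl on an aromatic carbon. Compound 3 `CNC(=O)/C=C/c1ccncc1-c1ccc2[nH]ccc2c1` also bears an ethenyl chain yet reads > 10000 nM as a limit, so no clear gain is expected for compound 4. In this assay the expected move is small and without firm direction, estimated as a step that the limit leaves unreadable from compound 2 to compound 4 here. For compound 4 the estimate is 15000 nM with an expected range of 6000 nM to 40000 nM and another limit is the likeliest report.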

Compound 4, concentration for 50% growth inhibition: 6050 nM
Compound 4: the middle estimate sits 2.5-fold (0.39 log units) above what was measured; measured number inside the range.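

Among the compounds shown here, at this position, on an aromatic carbon opposite the ring nitrogen, 2-(cyclopropylcarbamoyl)ethenyl in place of 2-(methylcarbamoyl)ethyl gives an at least 1.6-fold lower number from compound 2 to compound 4 (0.21 log units; that floor lies within the scatter) in this assay and the only actual number in the row. That floor lies within the scatter, so the step is not yet shown to be a firm gain, and its true size remains unknown. Compound 4 alone stands clear of the limit: the limit of > 10000 nM in this assay, at which 3 of the 4 values shown sit.

The step changes both the chain's double bond and the cyclopropyl ring, and the compounds shown do not separate the two. Going by these compounds, whether a cyclobutyl amide or a carboxylic acid on the same ethenyl chain would read lower stays open.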